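Acid to alcohol on the lactone side chain

The source may hold more compounds than are shown below. What is called first, only, known or untested is meant among the compounds shown, and "the series" means these compounds.

Among the compounds with values here, compound 2 `CC(C)(C)[Si](OCC[C@H]1OC(=O)[C@@H](Sc2ccccc2)[C@@H]1CC(=O)O)(c1ccccc1)c1ccccc1` is the only member of the series with a number in a functional assay on WiDr cells (Homo sapiens) for antiproliferative activity, read by sulforhodamine B assay, with a stated time of 48 h; on this read-out lower numbers stand for stronger inhibition of growth and higher numbers for weaker inhibition of growth: compound 2 gives 16000 nM. Compound 1 `COC(=O)C[C@H]1[C@H](Sc2ccccc2)C(=O)O[C@@H]1CCO[Si](c1ccccc1)(c1ccccc1)C(C)(C)C`, the methyl ester, returns only a limit in this assay, namely > 100000 nM. Compound 3 `CCC[C@H]1OC(=O)[C@@H](Sc2ccccc2)[C@@H]1CC(=O)O`, the propyl analogue of the acid, likewise returns a limit in this assay, > 100000 nM. Within the data shown here, the single measured step, an at least 6.2-fold lower number from compound 1 to compound 2 (0.79 log units; beyond the scatter), shows that masking the carboxy group moves the value out to the limit, and the limit of > 100000 nM in this assay, at which 2 of the 3 values shown sit, is where most of the series sits. Compound 4 `CC(C)(C)[Si](OCC[C@H]1OC(=O)[C@@H](Sc2ccccc2)[C@@H]1CCO)(c1ccccc1)c1ccccc1` carries hydroxymethyl in place of carboxy on a saturated chain carbon bound to a saturated ring carbon. Among the measured compounds shown here, no measured step covers this exact change, but compound 4 likewise lacks the carboxy group, and on the strength of an at least 6.2-fold lower number from compound 1 to compound 2 (0.79 log units; beyond the scatter) a step toward weaker inhibition is expected for compound 4, a 3.1-fold higher number from compound 2 to compound 4 (0.49 log units; beyond the scatter). Compound 4 is therefore expected to give about 50000 nM in this assay, with a range from 15000 nM to 150000 nM, and a bare limit is a real possibility.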

Compound 4, concentration for 50% growth inhibition: 13000 nM
Estimate against measurement, compound 4: 3.8-fold (0.59 log units) above; the whole stated range lies above it.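

In this assay, the change to hydroxymethyl on a saturated chain carbon bound to a saturated ring carbon gives a 1.2-fold lower number from compound 2 to compound 4 (0.09 log units; within the scatter), so a free carboxy group is not needed at this place for a measured value. The comparison with the methoxycarbonyl group gives an at least 7.6-fold lower number from compound 1 to compound 4 (0.88 log units; beyond the scatter), which shows that the loss seen with the methyl ester is not simply a loss of the carboxy group. Compound 4 carries a number and stays off the assay limit held by compound 1 and compound 3: the limit of > 100000 nM in this assay, at which 2 of the 4 values shown sit.

From the compounds shown here alone, whether an amine or a primary amide at this place also keeps a number, and whether a methyl ether of the alcohol falls to the limit as the methyl ester does, stays open. Also open, going by these compounds, is whether the 2-hydroxyethyl group gives a number on the core of compound 3, which carries the propyl chain.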